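The compounds below may be only part of what the source reports. "The series", "measured", "known", "first", "only" and "open" are said of these compounds alone.

Measured so far in a functional assay on LNCaP cells (Homo sapiens) for cytotoxicity; a lower number here means a stronger inhibitor, a higher number a weaker inhibitor:
- compound 1 `CNC(=O)Nc1ccc(-c2nc(N3CC4CCC(C3)O4)c3cnn(CCO)c3n2)cc1` gives 650 nM
- compound 2 `CNC(=O)Nc1ccc(-c2nc(N3CC4CCC(C3)O4)c3cnn([C@H]4CC[C@@H](O)CC4)c3n2)cc1` gives 20 nM
- compound 3 `CNC(=O)Nc1ccc(-c2nc(N3CC4CCC(C3)O4)c3cnn([C@H]4CC[C@@H](OC)CC4)c3n2)cc1` gives 1 nM

Compound 3 stands at the lowest number of the three; the step of a 20-fold lower number from compound 2 to compound 3 (1.30 log units; beyond the scatter) and the step of a 650-fold lower number from compound 1 to compound 3 (2.81 log units; beyond the scatter) both lie beyond the scatter, so compound 3 is the strongest inhibitor measured here.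

The next compound, compound 4 `CNC(=O)Nc1ccc(-c2nc(N3CC4CCC(C3)O4)c3cnn([C@H]4CC[C@H](O)CC4)c3n2)cc1`, is not yet measured. The change from compound 3 is 4-hydroxycyclohexyl in place of 4-methoxycyclohexyl on an aromatic nitrogen. Within the data shown here, only one measured step bears directly on it: the step of a 20-fold lower number from compound 2 to compound 3 (1.30 log units; beyond the scatter), which is the same exchange run the other way, since compound 2 also carries a 4-hydroxycyclohexyl on the aromatic nitrogen. Among the measured compounds shown here, compound 4 is a stereoisomer of compound 2 and no step between the two is available, so the stereochemistry of the hydroxyl cannot be weighed from these data. Reversing the methylation step is therefore expected to give a higher number, a step of about a 30-fold higher number from compound 3 to compound 4 (1.48 log units; beyond the scatter), landing near where compound 2 stands. Compound 4 is estimated at 30 nM, with a range from 8 nM to 120 nM.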

Compound 4, half-maximal inhibitory concentration: 20 nM
Compound 4: middle estimate off by 1.5-fold (0.18 log units), on the high side; the measured number falls inside the stated range.
By their numbers in this assay, from the lowest: compound 3; then compounds 2 and 4 (each within the scatter of the next); then compound 1.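

In this assay there is no change at the digits printed from compound 2 to compound 4 (within the scatter), so the two drawings of the 4-hydroxycyclohexyl group on the aromatic nitrogen are not told apart by this read-out. The exchange of 4-methoxycyclohexyl for 4-hydroxycyclohexyl now gives a 20-fold higher number from compound 3 to compound 4 (1.30 log units; beyond the scatter), matching a 20-fold lower number from compound 2 to compound 3 (1.30 log units; beyond the scatter) in size across both drawings, and the advantage over 2-hydroxyethyl also recurs, with a 33-fold lower number from compound 1 to compound 4 (1.51 log units; beyond the scatter). Even so, the pair cannot be read as a clean test of the hydroxyl orientation because of how the two compounds are drawn: the fact that one of compounds 2 and 4 is drawn with a defined configuration and the other without, at the place where they differ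

On these data alone, whether a methoxy group in the other drawn configuration would stand with compound 3 remains open. Also open, as far as these compounds go, is how an amine or a longer ether such as ethoxy would fare in place of the methoxy on the cyclohexyl ring.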